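This account rests on a few compounds, and the source may have more. Where it says the series, first, only, none or still open, it means among the compounds named here.

Working notes on a functional assay on CCRF-CEM cells (Homo sapiens) for inhibition; a higher number here means a weaker inhibitor, a lower number a stronger inhibitor. Of the compounds shown here, three have numbers so far. Compound 1 `O=C1/C(=C/c2cccc([N+](=O)[O-])c2)CCCc2ccccc21` gives 7720 nM, and its core differs from the one shared by the other two. Compound 2 `O=C1CCCCC/C1=C\c1ccc(F)cc1` gives 198000 nM. Compound 3 `O=C1CCCCC/C1=C\c1ccc(Cl)cc1` gives 43500 nM, the middle of the three numbers, lower than the value for compound 2 and higher than the value for compound 1.

Compound 4 `CN(C)c1ccc(/C=C2\CCCCCC2=O)cc1` is not yet measured. It arises from compound 3 by one change, dimethylamino in place of chloro on an aromatic carbon. For the measured compounds named here, only one measured step bears on this place, a 4.6-fold lower number from compound 2 to compound 3 (0.66 log units; beyond the scatter). That step is modest but beyond the scatter, and it exchanges one halogen for another. Going by the values given here, it shows that the number can move with the group at this place, but no measured compound carries dimethylamino, so the direction of the new step stays open. The central expectation in this assay is therefore little change, with room on either side for a modest step of about the size seen with chloro in place of fluoro. The expected step is a 1.2-fold lower number from compound 3 to compound 4 (0.09 log units; within the scatter). Compound 4 is estimated at 35000 nM, with an expected range of 10000 nM to 130000 nM.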

Compound 4, half-maximal inhibitory concentration: 45100 nM
Compound 4: the middle estimate sits 1.3-fold (0.11 log units) below what was measured; measured number inside the range.
By their numbers in this assay, from the lowest: compound 1; then compounds 3 and 4 (each within the scatter of the next); then compound 2.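

In this assay, chloro and dimethylamino on this aromatic carbon cannot be told apart, with a 1.0-fold higher number from compound 3 to compound 4 (0.02 log units; within the scatter), even though the entering group brings 3 heavy atoms against 1 and a hydrogen-bond acceptor that chloro lacks. Fluoro now stands apart from both of the other groups at this place: a 4.4-fold lower number from compound 2 to compound 4 (0.64 log units; beyond the scatter), a step of much the same size as a 4.6-fold lower number from compound 2 to compound 3 (0.66 log units; beyond the scatter), so two quite different replacements of fluoro both end beyond the scatter of compound 2 and within the scatter of each other. No measurement available on these compounds speaks to what lies behind this pattern.

On these data alone, whether the level shared by compound 3 and compound 4 persists for other groups on this aromatic carbon remains open, for example a carboxylic acid, a methoxy group, or an amine with longer chains such as diethylamino. Also open, as far as these compounds go, is whether exchanging fluoro for chloro or dimethylamino would give a step of similar size on the core of compound 1.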